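The source may report more compounds than this note shows. Statements on the series, on what has been measured and on what is new or still open speak of the compounds shown alone.

Compound 1 `CC(C)(CNC(=O)c1ccc2ccccc2c1)CC1=C(O)C(=O)c2ccccc2C1=O` gives 46700 nM in an ADME assay on Vero cells (Chlorocebus sabaeus) for cytotoxicity, read by fluorescence, with a stated time of 4 days; a higher number here means a weaker inhibitor, a lower number a stronger inhibitor. Compound 2 `COC1=C(CC(C)(C)CNC(=O)c2ccc3ccccc3c2OC)C(=O)c2ccccc2C1=O` gives 60600 nM in this assay; its number and that of compound 1 lie within the scatter of each other, so the two stand together. Compound 3 `COc1c(C(=O)NCC(C)(C)CC2=C(O)C(=O)c3ccccc3C2=O)ccc2ccccc12` differs from compound 2 by hydrogen in place of methyl on an oxygen on an unsaturated carbon. Among the compounds with values here, no step between measured compounds matches this change, and the two measured numbers sit within the scatter of one another, so no step beyond the scatter is expected here. Compound 3 is therefore expected to give 52000 nM in this assay, within 25000 nM to 110000 nM, which would mean an expected 1.2-fold lower number from compound 2 to compound 3 (0.07 log units; within the scatter).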

Compound 3, half-maximal inhibitory concentration: 47300 nM
For compound 3 the middle estimate is 1.1-fold (0.04 log units) above the measured one; low and high end bracket the measured number.
By their numbers in this assay, from the lowest: compounds 1, 3 and 2 (each within the scatter of the next).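

In this assay, hydrogen in place of methyl on the oxygen on an unsaturated carbon gives a 1.3-fold lower number from compound 2 to compound 3 (0.11 log units; within the scatter), so compound 2 and compound 3 stand together at this place. Methoxy in place of hydrogen on an aromatic carbon gives a 1.0-fold higher number from compound 1 to compound 3 (0.01 log units; within the scatter), which also lies within the scatter. Nothing available here bears on these results.

The compounds shown leave open whether an amine or a carboxylic acid on that aromatic carbon would give a number beyond the scatter. They also leave open whether a longer chain on that oxygen would do so.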